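A few compounds are considered here, and "the series" means these few. Any claim that something is new, unique, unknown or untested is made for them only; others in the source may bear on it.

Of the compounds shown here, three built on a shared core have been read in an ADME assay on MDCKII-LE cells (Canis lupus familiaris) for permeability, read by transwell migration, in the apical to basolateral direction; on this read-out higher numbers stand for higher permeability and lower numbers for lower permeability. Compound 1 (`CC1(C)C[C@@H](CN([C@H](CCC(F)(F)F)C(N)=O)S(=O)(=O)c2ccc(Cl)cc2)O1`) gives 14.9 10^-6 cm/s, compound 2 (`NC(=O)[C@@H](CCC(F)(F)F)N(C[C@@H]1CCCCO1)S(=O)(=O)c1ccc(Cl)cc1`) gives 15.4 10^-6 cm/s and compound 3 (`NC(=O)[C@@H](CCC(F)(F)F)N(C[C@@H]1CCCOC1)S(=O)(=O)c1ccc(Cl)cc1`) gives 18.4 10^-6 cm/s. Compound 3 therefore stands within the scatter of both other compounds, and the three numbers set up no order among themselves. Compound 4 (`NC(=O)[C@@H](CCC(F)(F)F)N(CC1CCOCC1)S(=O)(=O)c1ccc(Cl)cc1`) has the same atoms as compound 3, joined differently: oxan-4-yl in place of oxan-3-yl on a saturated chain carbon bound to a sulfonamide nitrogen. In words, oxan-4-yl stands in place of oxan-3-yl on a saturated chain carbon bound to a sulfonamide nitrogen. The closest measured change at this place is a 1.2-fold higher number from compound 2 to compound 3 (0.08 log units; within the scatter), which also moves between oxane attachments and lies within the scatter. The changes a 1.0-fold higher number from compound 1 to compound 2 (0.01 log units; within the scatter) and a 1.2-fold higher number from compound 1 to compound 3 (0.09 log units; within the scatter) at the same place lie within the scatter too. No measured change here has left the scatter, so no real shift is expected in this assay. The expected change, a 1.1-fold lower number from compound 3 to compound 4 (0.03 log units; within the scatter), is estimated to stay within the scatter. For compound 4 the estimated value is 17 10^-6 cm/s, with an expected range of 10 10^-6 cm/s to 27 10^-6 cm/s.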

Compound 4, apparent permeability: 26.3 10^-6 cm/s
For compound 4 the middle estimate is 1.5-fold (0.19 log units) below the measured one, and the stated range covers the measured number.
By their numbers in this assay, from the lowest: compounds 1, 2, 3 and 4 (each within the scatter of the next).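

In this assay the oxane attachment now reaches oxan-4-yl, and the step from oxan-3-yl stays within the scatter (a 1.4-fold higher number from compound 3 to compound 4 (0.16 log units; within the scatter)), as does the step from oxan-2-yl (a 1.7-fold higher number from compound 2 to compound 4 (0.23 log units; within the scatter)). The largest step at this position so far, from 4,4-dimethyloxetan-2-yl (a 1.8-fold higher number from compound 1 to compound 4 (0.25 log units; within the scatter)), also stays within the scatter, so on a saturated chain carbon bound to a sulfonamide nitrogen none of the four groups shown separates from the others on this read-out. No measured evidence is available that bears on this result.

The compounds shown leave open whether an amine or a carboxylic acid in place of the oxane would move the number beyond the scatter. From the compounds shown here alone, a longer chain at this place remains equally open.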